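A few compounds are considered here, and "the series" means these few. Any claim that something is new, unique, unknown or untested is made for them only; others in the source may bear on it.

Measured so far in a functional assay on the whole organism for inhibition, with Rattus norvegicus as the target; a higher number here means that more compound is needed for the effect, a lower number that less compound is needed:
- compound 1, `CC1CC/C(=N\Nc2cccc(Cl)c2)c2ncc(C(=O)O)c(=O)n21`, gives > 100 umol/kg, a limit of the assay and not a number.
- compound 2, `CC1CC/C(=N\Nc2cccc(I)c2)c2ncc(C(=O)O)c(=O)n21`, gives 1000 umol/kg.
- compound 3, `CC1CC/C(=N\Nc2ccc(O)cc2)c2ncc(C(=O)O)c(=O)n21`, gives > 100 umol/kg, again a limit of the assay and not a number.

Compound 3 therefore stands only at a limit in this assay, and of the three values shown two sit at that limit, as the limit of > 100 umol/kg in this assay, at which 2 of the 3 values shown sit, records. None of the steps among the measured compounds can be read: a step that the limit leaves unreadable from compound 1 to compound 2, a step that the two limits leave unreadable from compound 1 to compound 3 and a step that the limit leaves unreadable from compound 2 to compound 3 are all left unreadable by the limits, so the aryl changes on the amine nitrogen give no usable size.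

Compound 4, `C[C@@H]1CC/C(=N\Nc2ccc(O)cc2)c2ncc(C(=O)O)c(=O)n21`, is now to be measured in this assay. It differs from compound 3 as follows: the two compounds have the same atoms and bonds; at least one stereo element is drawn with a configuration in one of them and without one in the other: 1 of 2 stereo elements differ; a stereocentre at a saturated ring carbon is drawn without a configuration in compound 3 and R in compound 4. Within the data shown here, no measured step concerns a stereocentre, so nothing here bears directly on this change. With the same atoms and bonds, and with compound 3 at a limit, the expected step that the limit leaves unreadable from compound 3 to compound 4 is no more than the scatter, and the most likely outcome is that compound 4 also reports only a limit. The estimate for compound 4 in this assay is 200 umol/kg, within a range from 50 umol/kg to 1000 umol/kg.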

Compound 4, dose for 50% inhibition: > 100 umol/kg
Compound 4: no number, only a limit (the forecaster's own chance of this, stated with the estimate: 70%); the middle value does not contradict the limit.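

In this assay, among these compounds, compound 3 and compound 4 both report only a limit of the assay, so no step between them can be read: the limit of > 100 umol/kg in this assay, at which 3 of the 4 values shown sit. The compounds shown leave open whether the configuration at the saturated ring carbon has any effect on the dose needed, the one difference in this pair being: the fact that one of compounds 3 and 4 is drawn with a defined configuration and the other without, at the place where they differ.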